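Removing a Methyl from an Aromatic Ether Ester

The source may hold more compounds than are shown below. What is called first, only, known or untested is meant among the compounds shown, and "the series" means these compounds.

Of the compounds shown here, three sharing a terpenoid-type core have been tested in a functional assay on SEM cells (Homo sapiens) for cytotoxicity, read by MTT assay, with a stated time of 72 h; on this read-out lower numbers stand for stronger inhibition and higher numbers for weaker inhibition. Compound 1 `C/C=C(\C)C(=O)O[C@H]1C[C@@]2(C)O[C@H]2[C@@H](OC(C)=O)[C@@]2(C)CC[C@@](O)(C(C)C)[C@H]12` carries an unsaturated ester on the core; in this assay compound 1 reaches only the limit of > 100000 nM, which is a boundary of the measurement rather than a number, a situation described in the limit of > 100000 nM in this assay, at which 1 of the 3 values shown sits. Compound 2 `CC1=CC[C@]2(C)[C@@H]([C@@H](OC(=O)c3ccc(O)cc3)C1)[C@](O)(C(C)C)C[C@@H]2O` carries a 4-hydroxyphenyl ester and gives 22400 nM. Compound 3 `COc1ccc(C(=O)O[C@H]2CC(C)=CC[C@@]3(C)CC[C@@](O)(C(C)C)[C@H]23)cc1`, with a 4-methoxyphenyl ester, gives 18200 nM; the numbers of compound 3 and compound 2 lie within the usual scatter of each other, so neither can be called the stronger one.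

The next compound, compound 4 `CC1=CC[C@@]2(C)CC[C@@](O)(C(C)C)[C@@H]2[C@@H](OC(=O)c2ccc(O)cc2)C1`, differs from compound 3 in one place: hydrogen in place of methyl on an oxygen on an aromatic ring. The same change is not seen as an isolated step among the measured compounds, but compound 2 already carries a 4-hydroxyphenyl ester on a related core and sits close to compound 3. No change beyond the scatter is therefore expected from compound 3 to compound 4, and the expected step is a 1.1-fold higher number from compound 3 to compound 4 (0.04 log units; within the scatter). Compound 4 is estimated to give 20000 nM in this assay, within a range from 7000 nM to 60000 nM.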

Compound 4, half-maximal inhibitory concentration: > 100000 nM
Compound 4: no number, only a limit; the forecaster's own chance of this, stated with the estimate: 10%; middle value at least 5.0-fold (0.69 log units) away from the limit.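

In this assay, among these compounds, the change from 4-methoxyphenyl to 4-hydroxyphenyl gives an at least 5.4-fold higher number from compound 3 to compound 4 (0.73 log units; beyond the scatter), so the methyl on this oxygen makes a difference on this core that the earlier compounds could not reveal. Compound 2 had suggested that a 4-hydroxyphenyl ester could sit on a related core with a measurable value, yet hydrogen in place of hydroxy on a saturated ring carbon gives an at least 4.4-fold higher number from compound 2 to compound 4 (0.64 log units; beyond the scatter), which shows that the 4-hydroxyphenyl ester alone does not set the read-out. Compound 4 gives a limit and not a number, so both steps are minimum sizes and their true sizes cannot be read: the limit of > 100000 nM in this assay, at which 2 of the 4 values shown sit.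

The compounds shown leave open whether the methyl itself is needed or whether an ethyl group or a longer chain on the same oxygen would serve as well. They also leave open what the hydroxy on the saturated ring carbon would do alongside a 4-methoxyphenyl ester, since no compound shown carries both groups.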